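A few compounds are considered here, and "the series" means these few. Any claim that something is new, unique, unknown or untested is made for them only; others in the source may bear on it.

Of the compounds shown here, two with the same core have been measured so far, and they differ only in the group on the amine nitrogen of the six-membered ring. Compound 1 `CCCn1c(=O)[nH]c2nc(-c3ccc(S(=O)(=O)N4CCN(c5ccccc5Br)CC4)cc3)[nH]c2c1=O` and compound 2 `CCCn1c(=O)[nH]c2nc(-c3ccc(S(=O)(=O)N4CCN(c5ccccc5Cl)CC4)cc3)[nH]c2c1=O` were both tested in an assay on CHO cells for displacement of a labelled ligand from adenosine receptor A1 (Homo sapiens), read by scintillation counting, with a stated time of 90 min, tested at 1 uM, in the presence of a further agent that is not named here; a lower number here means less inhibition, a higher number more inhibition at the concentration tested (going by the name of the read-out). In this assay compound 1 gives 28%, and compound 2 gives 25%. Within the data shown here, the one measured step, a number 3 percentage points lower from compound 1 to compound 2 (within the scatter), is chloro in place of bromo on an aromatic carbon. Compound 2 therefore has the lowest of the two numbers, though its nearest neighbour, compound 1, sits within the scatter of it, so no order between them can be claimed.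

Compound 3 `CCCn1c(=O)[nH]c2nc(-c3ccc(S(=O)(=O)N4CCN(c5ccc(Cl)cc5F)CC4)cc3)[nH]c2c1=O` has not yet been measured. It differs from compound 2 in one place: 4-chloro-2-fluorophenyl in place of 2-chlorophenyl on an amine nitrogen in a ring. Among the measured compounds shown here, the only step that bears on this is a number 3 percentage points lower from compound 1 to compound 2 (within the scatter), a change of halogen on the same aromatic ring, which stayed within the scatter. On that basis the expected step is no change at the digits printed from compound 2 to compound 3 (within the scatter), that is, none beyond the scatter. Compound 3 is thus estimated at 25%, with a range from 10% to 40%.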

Compound 3, a percentage reported as inhibition, at one concentration (the size of the read-out at that concentration, not a potency): 9%
The estimate for compound 3 lay 16 percentage points above the measured number; measured number outside the range, below it.
By their numbers in this assay, from the lowest: compound 3; then compounds 2 and 1 (each within the scatter of the next).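

The group on the amine nitrogen in the ring can move the result in this assay after all: putting 4-chloro-2-fluorophenyl in place of 2-chlorophenyl gives a number 16 percentage points lower from compound 2 to compound 3 (beyond the scatter) and so goes further than the exchange of one halogen for another, which stayed within the scatter. The same replacement starting from 2-bromophenyl gives a number 19 percentage points lower from compound 1 to compound 3 (beyond the scatter) and points the same way, so the lower number for compound 3 holds against both earlier compounds, not just one of them. Nothing measured on these compounds says why the number fell at this position.

This change does two things at once, since the new group carries a fluorine at the 2-position and its chlorine at the 4-position, and these three compounds cannot show which of the two matters, or whether both are needed. A plain 2-fluorophenyl or 4-chlorophenyl group on the same nitrogen would separate the two, and a group with no halogen at all, such as unsubstituted phenyl or 2-methoxyphenyl, would show how much the halogens contribute at this position.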